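Chloro for fluoro and tolerated concentration: notes on four compounds

The source may hold more compounds than are shown below. What is called first, only, known or untested is meant among the compounds shown, and "the series" means these compounds.

Measured so far:
compound 1 `O=C1/C(=C/c2ccc(F)cc2)CCC/C1=C\c1ccccc1[N+](=O)[O-]`: 67000 nM
compound 2 `O=C1/C(=C/c2ccc(Cl)cc2)CCC/C1=C\c1ccccc1[N+](=O)[O-]`: > 400000 nM (a limit of the assay)
compound 3 `O=C1/C(=C/c2ccc(F)cc2)CCC/C1=C\c1ccc([N+](=O)[O-])cc1`: > 400000 nM (a limit of the assay)

In an ADME assay on HPLF cells (Homo sapiens) for cytotoxicity, with a stated time of 24 h (a higher number here means that more compound is tolerated, a lower number that less compound is tolerated), compound 1 gives 67000 nM. For compound 2 the value in this assay is a limit of the assay, > 400000 nM. The change from compound 1 to compound 2 is chloro in place of fluoro on an aromatic carbon, and the step is an at least 5.9-fold higher number from compound 1 to compound 2 (0.77 log units; beyond the scatter); it is known only as a bound because of the limit of > 400000 nM in this assay, at which 2 of the 3 values shown sit. Compound 3 also reaches only a limit of the assay in this assay, > 400000 nM. How the core of compound 3 differs from that of compound 1 is not broken down here. Compound 4 `O=C1/C(=C/c2ccc(Cl)cc2)CCC/C1=C\c1ccc([N+](=O)[O-])cc1` is not yet measured; it differs from compound 3 by chloro in place of fluoro on an aromatic carbon, the same change as that from compound 1 to compound 2. Given the step of an at least 5.9-fold higher number from compound 1 to compound 2 (0.77 log units; beyond the scatter), compound 4 is expected to give 400000 nM, most likely again as a limit, within 200000 nM to 800000 nM. The expected step is a number no higher from compound 3 to compound 4 (the limit leaves the size open).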

Compound 4, half-maximal cytotoxic concentration: 332000 nM
Compound 4: middle estimate off by 1.2-fold (0.08 log units), on the high side; the range from low to high includes it.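

In this assay, chloro in place of fluoro gives an at least 1.2-fold lower number from compound 3 to compound 4 (0.08 log units; that floor lies within the scatter), so the step seen on the core of compound 1 does not carry over unchanged to the core of compound 3: the same change on two cores in this assay, an at least 5.9-fold higher number (0.77 log units; beyond the scatter) from compound 1 to compound 2 and an at least 1.2-fold lower number (0.08 log units; that floor lies within the scatter) from compound 3 to compound 4, at least 7.1-fold (0.85 log units) apart, beyond the scatter of two such steps The sizes of both steps remain bounds, and the true gap between them could be wider, because the values at one end of each step sit at a limit: the limit of > 400000 nM in this assay, at which 2 of the 4 values shown sit. Two cores show only that the outcome of this change can depend on the core, and they give neither a rule for the series nor a reason for the difference.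

On these data alone, it remains open whether bromo or methoxy in place of the halogen would behave as in compound 2 or as in compound 4. Also open, as far as these compounds go, is how chloro for fluoro behaves on a core carrying an amine or a carboxylic acid.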